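Chain shortening on the nitro core of the hydroxamate series

This account rests on a few compounds, and the source may have more. Where it says the series, first, only, none or still open, it means among the compounds named here.

Compound 1 `Cc1ccc2nc(NC(=O)CCCCCCC(=O)NO)sc2c1` gives 0.54 ug/mL in a functional assay on ASPC1 cells (Homo sapiens) for cytotoxicity; a lower number here means a stronger inhibitor, a higher number a weaker inhibitor. Compound 2 `Cc1ccc2nc(NC(=O)CCCCC(=O)NO)sc2c1` gives 13.3 ug/mL in this assay; the change between them is hydroxycarbamoyl in place of 2-(hydroxycarbamoyl)ethyl on a saturated chain carbon, four bonds along the chain from a carbonyl carbon, and the step is a 25-fold higher number from compound 1 to compound 2 (1.39 log units; beyond the scatter). Compound 3 `O=C(CCCCCCC(=O)Nc1nc2ccc([N+](=O)[O-])cc2s1)NO` gives 1.65 ug/mL in this assay; its core differs from that of compound 1 by nitro in place of methyl on an aromatic carbon, and the step is a 3.1-fold higher number from compound 1 to compound 3 (0.49 log units; beyond the scatter). Compound 4 `O=C(CCCCC(=O)Nc1nc2ccc([N+](=O)[O-])cc2s1)NO` has not been measured; it differs from compound 3 by hydroxycarbamoyl in place of 2-(hydroxycarbamoyl)ethyl on a saturated chain carbon, four bonds along the chain from a carbonyl carbon, the same change that turns compound 1 into compound 2, now made on the core of compound 3. For compound 4 a step of a 20-fold higher number from compound 3 to compound 4 (1.30 log units; beyond the scatter) is expected, of about the same size as the earlier one, because the same change gave a 25-fold higher number from compound 1 to compound 2 (1.39 log units; beyond the scatter). Compound 4 is estimated at 33 ug/mL in this assay, expected between 12 ug/mL and 90 ug/mL.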

Compound 4, half-maximal inhibitory concentration: > 30 ug/mL
Compound 4 was reported as a limit; the forecaster's own chance of this, stated with the estimate: 10%; the middle value lies beyond the limit too.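

In this assay compound 4 is a limit, not a number: the limit of > 30 ug/mL in this assay, at which 1 of the 4 values shown sits. The shortened chain again gives a higher number on the nitro core, with an at least 18-fold higher number from compound 3 to compound 4 (1.25 log units; beyond the scatter), so the direction carries over, but equal size on the two cores is not shown: the same change on two cores in this assay, a 25-fold higher number (1.39 log units; beyond the scatter) from compound 1 to compound 2 and an at least 18-fold higher number (1.25 log units; beyond the scatter) from compound 3 to compound 4; the limit leaves it open whether they differ. Nitro in place of methyl also points the same way on the shorter chain, with an at least 2.2-fold higher number from compound 2 to compound 4 (0.35 log units; beyond the scatter), and again only the direction can be read: the same change on two cores in this assay, a 3.1-fold higher number (0.49 log units; beyond the scatter) from compound 1 to compound 3 and an at least 2.2-fold higher number (0.35 log units; beyond the scatter) from compound 2 to compound 4; the limit leaves it open whether they differ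

Still open, on these data alone, is how far compound 4 actually lies past the limit. Also open, as far as these compounds go, are whether the shortening behaves alike on a core carrying an amine in place of methyl or nitro, and how a longer chain fares on either core.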